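Amine-bearing aryl variant in the trifluoromethyl series

The source may hold more compounds than are shown below. What is called first, only, known or untested is meant among the compounds shown, and "the series" means these compounds.

Measured compounds:
Compound 1 `Cc1ccc(Cl)cc1N1CCN(c2ncnc3[nH]ncc23)CC1` — 13 nM
Compound 2 `Cc1ccc(Cl)cc1N1CCN(c2ncnc3[nH]nc(C(F)(F)F)c23)CC1` — 29 nM

In an assay for inhibition of ribosomal protein S6 kinase beta-1 variant D18H,T412E (Homo sapiens), read by a luciferase reporter and chemiluminescence, with a stated time of 3 h (a higher number here means a weaker inhibitor, a lower number a stronger inhibitor), compound 2 stands highest of the two numbers; the step of a 2.2-fold higher number from compound 1 to compound 2 (0.35 log units; beyond the scatter) separates it from the nearest value. Compound 3 `Cc1c(NCCN(C)C)cc(Cl)cc1N1CCN(c2ncnc3[nH]nc(C(F)(F)F)c23)CC1` differs from compound 2 by (2-(dimethylamino)ethyl)amino in place of hydrogen on an aromatic carbon. Going by the values given here, no measured step bears on this change: the single known step, from compound 1 to compound 2, concerns a different group and was modest. The data therefore give no direction, and the expectation rests on compound 2 alone, with wide uncertainty. The expected step is a 1.0-fold higher number from compound 2 to compound 3 (0.01 log units; within the scatter). Compound 3 is estimated at 30 nM, with a range from 8 nM to 120 nM.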

Compound 3, half-maximal inhibitory concentration: 4 nM
Estimate against measurement, compound 3: 7.5-fold (0.88 log units) above; measured number below the stated range.
By their numbers in this assay, from the lowest: compound 3; then compound 1; then compound 2.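

In this assay the aromatic carbon ortho to a methyl group accepts far more than hydrogen: (2-(dimethylamino)ethyl)amino gives a 7.3-fold lower number from compound 2 to compound 3 (0.86 log units; beyond the scatter) in the trifluoromethyl series. The earlier compounds shown here carried only hydrogen on this carbon, so they gave no reading of substitution there. No evidence at hand bears on the reason for this step.

Open, from the compounds shown here alone, is whether the terminal dimethylamino group matters or the aryl amine nitrogen alone suffices, which a simple amine, a methoxyethylamino chain or a longer chain would separate. Also open, going by these compounds, is whether the same step holds on the core of compound 1, which has hydrogen in place of trifluoromethyl.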